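Diethylamino in place of dimethylamino on compound 3

A few compounds are considered here, and "the series" means these few. Any claim that something is new, unique, unknown or untested is made for them only; others in the source may bear on it.

Going by the values given here, in a functional assay on K562 cells (Homo sapiens) for antiproliferative activity, read by MTT assay, with a stated time of 48 h (a lower number here means a stronger inhibitor, a higher number a weaker inhibitor), compound 3 `CN(C)CCCCn1c(N)c(-c2nc3cc(Cl)ccc3[nH]2)c2nc(C#N)c(C#N)nc21` gives 1930 nM, the lowest number so far, while compound 2 `CN(C)CCCn1c(N)c(-c2nc3cc(Cl)ccc3[nH]2)c2nc(C#N)c(C#N)nc21` gives 10700 nM. Compound 1 `CCN(CC)CCn1c(N)c(-c2nc3cc(Cl)ccc3[nH]2)c2nc(C#N)c(C#N)nc21` gives > 50000 nM, which is a limit of the assay. Compound 4 `CCN(CC)CCCCn1c(N)c(-c2nc3cc(Cl)ccc3[nH]2)c2nc(C#N)c(C#N)nc21` has diethylamino in place of dimethylamino on a saturated chain carbon, four bonds along the chain from an aromatic nitrogen. Among the compounds with values here, no measured pair makes this change alone. With dimethylamino kept, there is a 5.5-fold lower number from compound 2 to compound 3 (0.74 log units; beyond the scatter). With chain and amine altered together, there is an at least 25-fold lower number from compound 1 to compound 3 (1.41 log units; beyond the scatter). These steps leave room for a small rise at most, so the expected change in this assay is a 1.6-fold higher number from compound 3 to compound 4 (0.19 log units; within the scatter). For compound 4 the estimated value is 3000 nM, with an expected range of 1000 nM to 10000 nM.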

Compound 4, half-maximal inhibitory concentration: 1270 nM
The estimate for compound 4 lay 2.4-fold (0.37 log units) above the measured number; the range from low to high includes it.
By their numbers in this assay, from the lowest: compounds 4 and 3 (each within the scatter of the next); then compound 2. At a limit, above all of these: compound 1.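

In this assay, the change from dimethylamino to diethylamino at this position, four bonds along the chain from an aromatic nitrogen, now stands alone in one pair, and it gives a 1.5-fold lower number from compound 3 to compound 4 (0.18 log units; within the scatter); at this chain length, the two amines cannot be told apart. The chain-length gain seen with dimethylamino also holds for diethylamino, with an 8.4-fold lower number from compound 2 to compound 4 (0.93 log units; beyond the scatter). The step of an at least 39-fold lower number from compound 1 to compound 4 (1.59 log units; beyond the scatter) rests on a limit for compound 1, not a number: the limit of > 50000 nM in this assay, at which 1 of the 4 values shown sits.

Still open, on these data alone, is whether a ring amine such as morpholine or piperidine, or a longer chain, keeps this level.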